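The source may report more compounds than this note shows. Statements on the series, on what has been measured and on what is new or still open speak of the compounds shown alone.

Of the compounds shown here, two of a shared core have been measured in a functional assay on HepG2 cells (Homo sapiens) for antiproliferative activity, read by MTT assay, with a stated time of 72 h; on this read-out lower numbers stand for stronger inhibition and higher numbers for weaker inhibition. Compound 1, `COc1cc2c(Nc3ccc(C#N)cc3)ncnc2cc1OCCCN1CCC(O)CC1`, gives 67900 nM. Within the data shown here, compound 2, `COc1cc2c(Nc3ccc(C#N)cc3)ncnc2cc1OCCCN1CCN(C)CC1`, gives 13800 nM, the lower of the two numbers; the only step on record, a 4.9-fold lower number from compound 1 to compound 2 (0.69 log units; beyond the scatter), separates them. Compound 2 thus stands as the stronger inhibitor of the pair, with no other measured neighbour.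

Compound 3, `COc1cc2c(Nc3ccc(C#N)cc3)ncnc2cc1OCCCN1CCN(c2ccncc2)CC1`, is reached from compound 2 by one change: pyridin-4-yl in place of methyl on an amine nitrogen in a ring. Among the measured compounds shown here, the one measured step bears on it only indirectly, since it exchanged the whole ring at that end of the chain rather than a group on the ring nitrogen, but it shows that alterations at this end of the chain can shift the read-out by a modest amount. For the measured compounds named here, with no measured example of an aryl group on that ring nitrogen, the direction of the change is open, and the expected step from compound 2 to compound 3 in this assay is small: a 1.5-fold lower number from compound 2 to compound 3 (0.19 log units; within the scatter). The estimate for compound 3 in this assay is therefore 9000 nM, with a range from 2500 nM to 35000 nM.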

Compound 3, half-maximal inhibitory concentration: 12600 nM
Beside the measured number, compound 3's estimate is 1.4-fold (0.15 log units) below it, and the stated range covers the measured number.
By their numbers in this assay, from the lowest: compounds 3 and 2 (each within the scatter of the next); then compound 1.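

In this assay, pyridin-4-yl in place of methyl on the amine nitrogen in the ring gives a 1.1-fold lower number from compound 2 to compound 3 (0.04 log units; within the scatter), so this position accepts a six-membered aromatic ring with 1 hetero atom while the numbers for the two compounds stay within the scatter of each other. The new compound also keeps the separation from the 4-hydroxypiperidin-1-yl end of the chain, with a 5.4-fold lower number from compound 1 to compound 3 (0.73 log units; beyond the scatter), a step beyond the scatter that matches a 4.9-fold lower number from compound 1 to compound 2 (0.69 log units; beyond the scatter) in being modest, so among these three compounds the separation from compound 1 holds with either methyl or pyridin-4-yl on the ring nitrogen. Nothing on record gives a reason for this result.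

The compounds shown leave open whether a plain phenyl ring, a pyridin-3-yl or pyridin-2-yl group, an acetyl group or a bare hydrogen on the same ring nitrogen would also stay within the scatter of compound 2. They also leave open how a shorter or longer chain would read with the 4-methylpiperazin-1-yl or 4-(pyridin-4-yl)piperazin-1-yl group at its end, and whether a morpholine or an open-chain dimethylamine at that end would read with these two or with compound 1.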